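This account rests on a few compounds, and the source may have more. Where it says the series, first, only, none or still open, it means among the compounds named here.

Measured compounds:
compound 1, `CCN(CC)CCCNc1ccnc2cc(Cl)ccc12` — 65300 nM
compound 2, `Clc1ccc2c(NCCCN3CCN(c4ccnc5cc(Cl)ccc45)CC3)ccnc2c1` — 8720 nM
compound 3, `FC(F)(F)c1ccc2c(N3CCN(CCCNc4ccnc5cc(Cl)ccc45)CC3)ccnc2c1` — 12900 nM

Among the compounds with values here, in an ADME assay on MCF-10A cells (Homo sapiens) for antiproliferative activity, read by sulforhodamine B assay, with a stated time of 48 h (a higher number here means a weaker inhibitor of growth, a lower number a stronger inhibitor of growth), compound 1 stands highest of the three numbers; no step to compound 2 or compound 3 is broken down, so only the values themselves are compared. Within the data shown here, the one change that is measured twice over is trifluoromethyl in place of chloro on an aromatic carbon, which gave a 1.5-fold higher number from compound 2 to compound 3 (0.17 log units; within the scatter). The difference between the core of compound 1 and the core of compound 2 is not broken down here.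

Compound 4, `CCN(CC)CCCNc1ccnc2cc(C(F)(F)F)ccc12`, is the unmeasured partner of compound 1 and carries the same change, (trifluoromethyl in place of chloro on an aromatic carbon), on the same place. Among the measured compounds shown here, from compound 1 to compound 4 a step of about a 1.3-fold higher number from compound 1 to compound 4 (0.11 log units; within the scatter) is expected in this assay, because the same change gave a 1.5-fold higher number from compound 2 to compound 3 (0.17 log units; within the scatter) and only that one step is known. Compound 4 is therefore estimated at 85000 nM, roughly between 35000 nM and 200000 nM.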

Compound 4, concentration for 50% growth inhibition: 45800 nM
Compound 4: the middle estimate sits 1.9-fold (0.27 log units) above what was measured; the range from low to high includes it.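

In this assay, trifluoromethyl in place of chloro on an aromatic carbon gives a 1.4-fold lower number from compound 1 to compound 4 (0.15 log units; within the scatter). Neither step on its own exceeds the scatter, and the two cores do not differ measurably in their response to this change: the same change on two cores in this assay, a 1.5-fold higher number (0.17 log units; within the scatter) from compound 2 to compound 3 and a 1.4-fold lower number (0.15 log units; within the scatter) from compound 1 to compound 4, 2.1-fold (0.32 log units) apart, within the scatter of two such steps. This shows that, on these two cores, the change leaves the number within the scatter, but two pairs cannot establish a shared direction or show that the same result would hold on other cores in the series.

The compounds shown leave open whether fluoro, methyl or a nitrile at the same place would give a step beyond the scatter. They also leave open whether the result holds on a core with a longer chain.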